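The source may hold more compounds than are shown below. What is called first, only, known or untested is meant among the compounds shown, and "the series" means these compounds.

Measured so far in an ADME assay on L02 cells (Homo sapiens) for cytotoxicity, read by MTT assay, with a stated time of 72 h; a higher number here means a weaker inhibitor, a lower number a stronger inhibitor:
- compound 1 `Cc1ccc(C(=O)/C=C/C(=O)N2CCc3cc(Nc4ncc(C)c(-c5cnn(C(C)C)c5)n4)ccc3C2)cc1`: 2660 nM
- compound 2 `Cc1cnc(Nc2ccc3c(c2)CCN(C(=O)/C=C/CN(C)C)C3)nc1-c1cnn(C(C)C)c1`: 7220 nM

Within the data shown here, compound 2 holds the highest of the two numbers in this assay; its nearest neighbour is compound 1, and the only measured step in the set is a 2.7-fold higher number from compound 1 to compound 2 (0.43 log units; beyond the scatter), a modest change confined to the end of the chain on the shared core.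

Compound 3 `COC(=O)/C=C/CN1CCc2cc(Nc3ncc(C)c(-c4cnn(C(C)C)c4)n3)ccc2C1` is not yet measured. Its difference from compound 2 is 3-(methoxycarbonyl)prop-2-en-1-yl in place of (3-(dimethylamino)prop-1-en-1-yl)carbonyl on an amine nitrogen in a ring. This change touches the same chain as the step from compound 1 to compound 2, but it also removes the carbonyl from the ring nitrogen, so that step bears on it only in part. Among the measured compounds shown here, no measured pair shows the effect of taking the carbonyl off the ring nitrogen, and nothing in the set speaks to direction with confidence. Given that the one known step at this chain was modest, a modest step is expected here as well, read as a 1.2-fold higher number from compound 2 to compound 3 (0.10 log units; within the scatter). Compound 3 is therefore estimated at 9000 nM, within a range of 3000 nM to 27000 nM.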

Compound 3, half-maximal inhibitory concentration: 1530 nM
Estimate against measurement, compound 3: 5.9-fold (0.77 log units) above; measured number below the stated range.
By their numbers in this assay, from the lowest: compounds 3 and 1 (each within the scatter of the next); then compound 2.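

In this assay, among these compounds, there is a 4.7-fold lower number from compound 2 to compound 3 (0.67 log units; beyond the scatter) and this shows that the group on the amine nitrogen in a ring can move the number beyond the scatter even when the carbonyl no longer sits directly on that nitrogen, which the earlier compounds, both carrying it, could not show. The step bundles two changes, since 3-(methoxycarbonyl)prop-2-en-1-yl differs from the leaving group both in where its carbonyl stands and in carrying no nitrogen, so it cannot be assigned to either one. The printed values of compound 1 and compound 3 lie within the scatter of each other, so a carbonyl on the ring nitrogen is not needed for a number at this level, and nothing among the data accounts for the shift.

Still open, going by these compounds, is whether the dimethylamino end or the position of the carbonyl matters more, and 3-(dimethylamino)prop-2-en-1-yl on the same ring nitrogen would separate the two. Also open, on these data alone, is how far the methoxycarbonyl end itself counts, which a free carboxylic acid or a primary amide at that chain end would test.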